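Cytotoxicity notes: from compound 3 to compound 4

This account rests on a few compounds, and the source may have more. Where it says the series, first, only, none or still open, it means among the compounds named here.

Measured in an ADME assay on BJ cells (Homo sapiens) for cytotoxicity, with a stated time of 72 h (on this read-out higher numbers stand for an effect only at larger amounts of compound and lower numbers for an effect already at smaller amounts), all three entries being limits:
- compound 1 `C=C[C@@](C)(/C=C/c1ccc(O)c(CO)c1)CCC=C(C)C` gives > 36600 nM
- compound 2 `C=C[C@@](C)(/C=C/c1ccc(O)c(/C=C/C(N)=O)c1)CCC=C(C)C` gives > 36600 nM
- compound 3 `C=C[C@@](C)(/C=C/c1ccc(O)c(/C=C(\C)C(=O)OCC)c1)CCC=C(C)C` gives > 36600 nM

Compound 3 gives > 36600 nM as a limit and not a number. Among the measured compounds shown here, the series so far offers only the limit of > 36600 nM in this assay, at which 3 of the 3 values shown sit, and no readable value to place it against.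

The next compound is compound 4 `CCOC(=O)/C(C)=C/c1cc(/C=C/[C@](C)(/C=C/c2ccc(OC)cc2)CCC=C(C)C)ccc1O` and the change is 2-(4-methoxyphenyl)ethenyl in place of vinyl on a saturated chain carbon bound to a double-bonded chain carbon and two saturated chain carbons with 2-(4-methoxyphenyl)ethenyl in place of vinyl on a saturated chain carbon bound to a double-bonded chain carbon and two saturated chain carbons.

Three measured steps exist: a step that the two limits leave unreadable from compound 1 to compound 2 and a step that the two limits leave unreadable from compound 1 to compound 3 and a step that the two limits leave unreadable from compound 2 to compound 3 as the third. All three concern a group on an aromatic carbon, not this chain carbon, and none has a readable size. They therefore give no measured size to carry over, and the expectation rests on the limit alone. No large change is expected, with only a slight lean towards lower numbers. The expected step is an at least 1.2-fold lower number from compound 3 to compound 4 (0.08 log units; that floor lies within the scatter) and it may well stay unreadable. Compound 4 is estimated at 30000 nM within a range from 12000 nM to 60000 nM in this assay and may again return only a limit.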

Compound 4, half-maximal effective concentration: > 36600 nM
Compound 4: a limit, no number; the forecaster's own chance of this, stated with the estimate: 65%; at least 1.2-fold (0.08 log units) between middle value and limit.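

In this assay compound 4 gives > 36600 nM, a limit and not a number. No size can be read for the step between compound 3 and compound 4, because both values are limits: the limit of > 36600 nM in this assay, at which 4 of the 4 values shown sit.

The compounds shown leave open whether 2-(4-methoxyphenyl)ethenyl in place of vinyl changes the read-out, and at what concentration any of them would show an effect in this assay.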